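Adding a Second Methoxy Group: What to Expect

A few compounds are considered here, and "the series" means these few. Any claim that something is new, unique, unknown or untested is made for them only; others in the source may bear on it.

Compound 1, `Cc1c(C(=O)/C=C/c2cccc([N+](=O)[O-])c2)[n+]([O-])c2ccccc2[n+]1[O-]`: 34000 nM
Compound 2, `COc1ccc(/C=C/C(=O)c2c(C)[n+]([O-])c3ccccc3[n+]2[O-])cc1`: 20000 nM

In a functional assay on HSC-2 cells (Homo sapiens) for cytotoxicity, with a stated time of 48 h (a lower number here means that less compound is tolerated, a higher number that more compound is tolerated), compound 1 gives 34000 nM. In the same test compound 2 gives 20000 nM. Among the measured compounds shown here, these are the only two numbers available, and the two lie within the usual scatter of each other, so the measurements do not separate compound 2 from compound 1 at all. For the measured compounds named here, the two compounds differ from each other at more than one place, so no single-change step between measured compounds can be drawn from them.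

Compound 3, `COc1ccc(/C=C/C(=O)c2c(C)[n+]([O-])c3ccccc3[n+]2[O-])cc1OC`, has not yet been measured. It differs from compound 2 by methoxy in place of hydrogen on an aromatic carbon. Going by the values given here, nothing among the measured compounds shows what such a change does to the half-maximal cytotoxic concentration, so the expectation is a cautious one: a step of no change at the digits printed from compound 2 to compound 3 (within the scatter) of no size beyond the scatter is expected. On that basis compound 3 is estimated to give 20000 nM in this assay, with a likely range from 8000 nM to 50000 nM.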

Compound 3, half-maximal cytotoxic concentration: 25000 nM
For compound 3 the middle estimate is 1.3-fold (0.10 log units) below the measured one, within the range that was stated.
By their numbers in this assay, from the lowest: compounds 2, 3 and 1 (each within the scatter of the next).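

In this assay, methoxy in place of hydrogen on an aromatic carbon, ortho to a methoxy group and meta to a large group, gives a 1.3-fold higher number from compound 2 to compound 3 (0.10 log units; within the scatter) and so does not separate the two compounds. Among the compounds shown here, this is the first single-change step, and it shows that adding these 2 heavy atoms at this position leaves the half-maximal cytotoxic concentration indistinguishable from that of the parent compound in this test. No measured information here explains the outcome.

Going by these compounds, it remains open whether an amine, a carboxylic acid or a longer chain such as ethoxy at this same aromatic carbon would produce a step beyond the scatter, since a methoxy group is the only replacement for hydrogen seen here. This single step also cannot show whether methoxy at this place would have the same outcome on a compound with a different substituent pattern, or whether the result is particular to the background of compound 2.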